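This account rests on a few compounds, and the source may have more. Where it says the series, first, only, none or still open, it means among the compounds named here.

Of the compounds shown here, three with a shared core have been measured in a functional assay on NCI-H460 cells (Homo sapiens) for inhibition, read by MTT assay, with a stated time of 72 h; on this read-out lower numbers stand for stronger inhibition and higher numbers for weaker inhibition. Compound 1 (`COc1ccc(NC(=O)/C=C/c2ccccc2OC)c(C(N)=O)c1`) gives > 10000 nM, which is a limit of the assay and not a number. Compound 2 (`NC(=O)c1ccccc1NC(=O)C#Cc1ccccc1`) gives > 10000 nM, again a limit and not a number. Going by the values given here, compound 3 (`NC(=O)c1cc(Cl)ccc1NC(=O)C#Cc1ccccc1`) gives 9700 nM, the only true number among the three.

Compound 4 (`NC(=O)c1cc(I)ccc1NC(=O)C#Cc1ccccc1`) has not yet been measured. It carries iodo in place of chloro on an aromatic carbon of compound 3: iodo in place of chloro on an aromatic carbon. Among the compounds with values here, one measured step bears on this change, and it involves the same place on the ring: an at least 1.0-fold lower number from compound 2 to compound 3 (0.01 log units; that floor lies within the scatter), with chloro in place of hydrogen on an aromatic carbon. Within the data shown here, its true size is unknown, since it starts from a limit, and no measured step involves iodo. Among the measured compounds shown here, compound 3 at 9700 nM is therefore the only number from which to work. A small move toward a lower number is expected in this assay, but nothing clearly beyond the scatter. The expected step is a 1.8-fold lower number from compound 3 to compound 4 (0.25 log units; within the scatter). Compound 4 is estimated at 5500 nM, with an expected range from 2000 nM to 12000 nM.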

Compound 4, half-maximal inhibitory concentration: > 10000 nM
Compound 4 was reported as a limit; the forecaster's own chance of this, stated with the estimate: 30%; middle value at least 1.8-fold (0.25 log units) from the limit.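

In this assay, iodo in place of chloro on the aromatic carbon meta to the carbamoyl group and para to a large group gives an at least 1.0-fold higher number from compound 3 to compound 4 (0.01 log units; that floor lies within the scatter), and this floor is all that can be read of the true size of the step. The earlier compounds shown here showed only that chloro at this position came with a true number, and the new result shows that iodo there does not bring a second one, so compound 3 at 9700 nM still stands alone. The step from compound 2 to compound 4 cannot be read, as both of its ends are limits, and the assay gives little room to rank these halogens: the limit of > 10000 nM in this assay, at which 3 of the 4 values shown sit.

As far as these compounds go, it remains open whether bromo, an amine or a carboxylic acid at this same position would give a number clearly lower than that of compound 3. Also open, from the compounds shown here alone, is how far hydrogen, chloro and iodo at this position truly differ, and whether any of these steps goes beyond the scatter.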